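Triazolyl sulfonamide series: notes toward compound 4

The compounds below may be only part of what the source reports. "The series", "measured", "known", "first", "only" and "open" are said of these compounds alone.

Compound 1 `O=c1[nH]cc(S(=O)(=O)Nc2ccccc2-c2cn(-c3ccccc3)nn2)c(=O)[nH]1`: 11800 nM
Compound 2 `O=c1[nH]cc(S(=O)(=O)Nc2ccccc2-c2cn(-c3ccccc3F)nn2)c(=O)[nH]1`: 10800 nM
Compound 3 `Cc1cccc(-n2cc(-c3cccc(NS(=O)(=O)c4c[nH]c(=O)[nH]c4=O)c3)nn2)c1`: 9100 nM

All three numbers come from a functional assay on SGC-7901 cells (Homo sapiens) for antiproliferative activity, read by MTT assay, with a stated time of 24 h; a lower number here means a stronger inhibitor, a higher number a weaker inhibitor. Compound 3 carries the lowest number of the three, yet its gaps to compound 2 and to compound 1 both fall within the scatter, so no ordering among them is claimed.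

Compound 4 `O=c1[nH]cc(S(=O)(=O)Nc2cccc(-c3cn(-c4ccc(Cl)cc4)nn3)c2)c(=O)[nH]1` differs from compound 3 in one place: 4-chlorophenyl in place of 3-methylphenyl on an aromatic nitrogen. Among the compounds with values here, the only single-place step measured so far, a 1.1-fold lower number from compound 1 to compound 2 (0.04 log units; within the scatter), also concerns a halogen on an aromatic carbon and stayed within the scatter; no measured step sets methyl against chlorine directly. On this basis the step of a 1.0-fold lower number from compound 3 to compound 4 (0.00 log units; within the scatter) is expected to remain within the scatter, in no particular direction. Compound 4 is accordingly estimated at 9000 nM, with a range from 4000 nM to 20000 nM.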

Compound 4, half-maximal inhibitory concentration: 2160 nM
Beside the measured number, compound 4's estimate is 4.2-fold (0.62 log units) above it, outside the stated range (below it).
By their numbers in this assay, from the lowest: compound 4; then compounds 3, 2 and 1 (each within the scatter of the next).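

In this assay, within the data shown here, the change of 3-methylphenyl to 4-chlorophenyl gives a 4.2-fold lower number from compound 3 to compound 4 (0.62 log units; beyond the scatter) and is the first single-place step here to pass the scatter, unlike a 1.1-fold lower number from compound 1 to compound 2 (0.04 log units; within the scatter) on an aromatic carbon. The aromatic nitrogen of the five-membered aromatic ring with 3 nitrogen is therefore a place where the number responds, although the groups match in heavy-atom count. No evidence on the origin of this step is available.

As far as these compounds go, whether the chlorine or its placement carries the step remains open. A 3-chlorophenyl or 4-methylphenyl group at this place would separate the two.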